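The compounds below may be only part of what the source reports. "The series", "measured", "known", "first", "only" and "open" are said of these compounds alone.

Measured so far:
- compound 1, `Cc1c(-n2c(-c3ccccc3)c(-c3ccccc3)c3c(Nc4ccccc4)ncnc32)n(C)n(-c2ccccc2)c1=O`: 13%
- compound 2, `Cc1nc2c(c(-c3ccccc3)c(-c3ccccc3)n2-c2c(C)c(=O)n(-c3ccccc3)n2C)c(=O)[nH]1`: 13.2%

Both were tested in a functional assay on the whole organism (strain Sprague-Dawley) for inhibition, with Rattus norvegicus as the target, read by paw edema, with stated times of 1 h and 3 h, at a dose of 70 mg/kg by the subcutaneous route; on this read-out lower numbers stand for less inhibition and higher numbers for more inhibition at the one dose given (going by the name of the read-out). Compound 1 gives the smaller of the two numbers, but the gap to compound 2 lies within the usual scatter, so the two values show the same result. Compound 3, `Cc1c(-n2c(-c3ccccc3)c(-c3ccccc3)c3c(N/N=C/c4ccccc4)ncnc32)n(C)n(-c2ccccc2)c1=O`, differs from compound 1 in one place: a group of 8 heavy atoms (7 carbon, 1 nitrogen; one six-membered aromatic ring of carbon only) in place of a group of 6 heavy atoms (6 carbon; one six-membered aromatic ring of carbon only), on a nitrogen on an aromatic ring. Within the data shown here, no measured pair differing in one place exists, so nothing shows how large such a change can be. The step from compound 1 to compound 3 is expected to be a number 3 percentage points higher from compound 1 to compound 3 (within the scatter), not beyond the scatter. Compound 3 is estimated at 16%, between 4% and 32%.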

Compound 3, a percentage reported as inhibition, in the whole organism at one dose (the size of the read-out at that dose, not a potency): 90.8%
The estimate for compound 3 lay 74.8 percentage points below the measured number; measured number above the stated range.
By their numbers in this assay, from the lowest: compounds 1 and 2 (each within the scatter of the next); then compound 3.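

In this assay, replacing phenyl with a group of 8 heavy atoms, on a nitrogen on an aromatic ring, gives a number 77.8 percentage points higher from compound 1 to compound 3 (beyond the scatter) in a single change. Among these compounds, the entering group keeps the six-membered aromatic ring but adds a nitrogen and a double bond outside that ring, so this position can strongly alter the read-out at this dose, something the earlier compounds could not show. Nothing available bears on why the number moves so far. The compounds shown leave open whether the added nitrogen, the double bond or the greater length accounts for the step. A benzyl group or a longer saturated carbon chain at this place is not among them.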